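A few compounds are considered here, and "the series" means these few. Any claim that something is new, unique, unknown or untested is made for them only; others in the source may bear on it.

Measured so far in a toxicity assay on HeLa cells (Homo sapiens) for cytotoxicity; on this read-out lower numbers stand for higher toxicity in this test and higher numbers for lower toxicity in this test:
Compound 1 `COc1nc(-c2ccc(Cl)cc2)ccc1[C@@H](c1ccccc1)[C@@](O)(CCN(C)C)c1cccc2ccccc12` gives a limit, > 64 ug/mL.
Compound 2 `COc1nc(C(C)(C)C)ccc1[C@@H](c1ccccc1)[C@@](O)(CCN(C)C)c1cccc2ccccc12` gives a limit, > 64 ug/mL.
Compound 3 `COc1nc(-c2ccncc2)ccc1[C@@H](c1ccccc1)[C@@](O)(CCN(C)C)c1cccc2ccccc12` gives 9.6 ug/mL.

For the measured compounds named here, compound 3 holds the only number in this assay; the other two values sit at a limit (the limit of > 64 ug/mL in this assay, at which 2 of the 3 values shown sit). Compound 4 `COc1nc(-c2ccccc2Cl)ccc1[C@@H](c1ccccc1)[C@@](O)(CCN(C)C)c1cccc2ccccc12` differs from compound 3 by 2-chlorophenyl in place of pyridin-4-yl on an aromatic carbon. Going by the values given here, two measured steps bear on this change, both leading toward pyridin-4-yl: an at least 6.6-fold lower number from compound 1 to compound 3 (0.82 log units; beyond the scatter) and an at least 6.6-fold lower number from compound 2 to compound 3 (0.82 log units; beyond the scatter). Compound 4 goes the other way, with 2-chlorophenyl entering where pyridin-4-yl leaves. Compound 1, which carries 4-chlorophenyl, is itself at the limit. A higher number, at least modest, is therefore expected in this assay for compound 4, a step of a 6.7-fold higher number from compound 3 to compound 4 (0.82 log units; beyond the scatter). Compound 4 is estimated at 64 ug/mL, within 25 ug/mL to 120 ug/mL, most likely reported only as a limit.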

Compound 4, half-maximal cytotoxic concentration: > 64 ug/mL
Compound 4: only a limit was reported (the forecaster's own chance of this, stated with the estimate: 70%); the middle value sits exactly at the limit.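

In this assay, 2-chlorophenyl in place of pyridin-4-yl on this carbon next to the ring nitrogen gives an at least 6.6-fold higher number from compound 3 to compound 4 (0.82 log units; beyond the scatter), so a chlorophenyl group with the chlorine placed differently from compound 1 also fails to give a number. Compound 4 gives only a limit, > 64 ug/mL, and the steps from compound 1 and compound 2 to it cannot be read. Pyridin-4-yl in compound 3 remains the only group here with a number, while the limit spreads: the limit of > 64 ug/mL in this assay, at which 3 of the 4 values shown sit.

Going by these compounds, whether the ring nitrogen of pyridin-4-yl matters, rather than the group as a whole, stays open, and pyridin-3-yl or a primary amine at this place would test that. On these data alone, what numbers lie behind the limits also stays open.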